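The source may hold more compounds than are shown below. What is called first, only, known or untested is meant among the compounds shown, and "the series" means these compounds.

In an ADME assay on microsomes from liver (Rattus norvegicus, strain Sprague-Dawley) for metabolic stability, read by LC-MS, using NADPH, with a stated time of 60 min, tested at 10 mM (on this read-out higher numbers stand for fast clearance and lower numbers for slow clearance), compound 1 (`O=Cc1c(-c2nc(NCCCCN3CCCC3)c3ccccc3n2)[nH]c2ccccc12`) gives 2.8 mL.min-1.g-1, while compound 2 (`COc1ccc2[nH]c(-c3nc(NCCN4CCCC4)c4ccccc4n3)c(C=O)c2c1`) gives 6.6 mL.min-1.g-1. Compound 2 therefore holds the higher of the two numbers, and the gap between them lies beyond the usual scatter. Compound 3 (`COc1ccc2[nH]c(-c3nc(NCCCCN4CCCC4)c4ccccc4n3)c(C=O)c2c1`) differs from compound 2 in one place: 2-(pyrrolidin-1-yl)ethyl in place of pyrrolidin-1-yl on a saturated chain carbon, two bonds along the chain from a nitrogen on an aromatic ring. In words, 2-(pyrrolidin-1-yl)ethyl stands in place of pyrrolidin-1-yl on a saturated chain carbon, two bonds along the chain from a nitrogen on an aromatic ring. Among the compounds with values here, no measured pair shows this change on its own, so the data do not reveal its size or direction in this assay. The expectation therefore starts from compound 2 at 6.6 mL.min-1.g-1, with no step beyond the scatter. The estimated step, a 1.2-fold lower number from compound 2 to compound 3 (0.08 log units; within the scatter), is expected to stay within that scatter. For compound 3, the estimated value is 5.5 mL.min-1.g-1, with an expected range of 2.5 mL.min-1.g-1 to 12 mL.min-1.g-1.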

Compound 3, intrinsic clearance in microsomes: 3.7 mL.min-1.g-1
The estimate for compound 3 lay 1.5-fold (0.17 log units) above the measured number; low and high end bracket the measured number.
By their numbers in this assay, from the lowest: compounds 1, 3 and 2 (each within the scatter of the next, the first and the last beyond it).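

Replacing (2-(pyrrolidin-1-yl)ethyl)amino with (4-(pyrrolidin-1-yl)butyl)amino in this assay gives a 1.8-fold lower number from compound 2 to compound 3 (0.25 log units; within the scatter), so this longer chain, taken on its own, cannot be told apart from repeat-to-repeat variation. Compound 3 also allows the methoxy to be read alone: methoxy in place of hydrogen on an aromatic carbon gives a 1.3-fold higher number from compound 1 to compound 3 (0.12 log units; within the scatter), which again stays within the scatter. Neither single change therefore shows a clear effect on clearance, and nothing available here offers an explanation for these numbers.

From the compounds shown here alone, it remains open whether a chain of intermediate length, as in (3-(pyrrolidin-1-yl)propyl)amino, would fit the same picture. Also open, going by these compounds, is whether a different amine at the chain end, such as morpholine or piperidine in place of pyrrolidine, would shift clearance beyond the scatter.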